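Swapping the pendant heterocycle for a pyridine

The compounds below may be only part of what the source reports. "The series", "measured", "known", "first", "only" and "open" are said of these compounds alone.

Measured so far:
compound 1, `Cc1cc(C)c(-c2cn(C)cn2)cc1NC(=O)c1ccc(OCc2ccccn2)cc1`, 8000 nM in a physicochemical assay for solubility, at pH 7.4; a lower number here means a less soluble compound, a higher number a more soluble compound;
compound 2, `Cc1cc(C)c(-c2c(C)nn(C)c2C)cc1NC(=O)c1ccc(OCc2ccccn2)cc1`, 35000 nM in this assay.

Compound 2 holds the highest of the two numbers in this assay; its nearest neighbour is compound 1, and the step of a 4.4-fold higher number from compound 1 to compound 2 (0.64 log units; beyond the scatter) lies beyond the scatter. The new compound 3, `Cc1cc(C)c(-c2cccnc2)cc1NC(=O)c1ccc(OCc2ccccn2)cc1`, differs from compound 2 in one place: pyridin-3-yl in place of 1,3,5-trimethyl-1H-pyrazol-4-yl on an aromatic carbon. Among the measured compounds shown here, only the step from compound 1 to compound 2 bears on this, and it shows that exchanging the group on that aromatic carbon can move the number by a modest amount. Because a 4.4-fold higher number from compound 1 to compound 2 (0.64 log units; beyond the scatter) went upward on entering the trimethylpyrazole, its departure is expected to send the number back down, though the pyridin-3-yl that enters is not the imidazole of compound 1, so the size is uncertain. Compound 3 is therefore estimated at 9000 nM, within 2500 nM to 30000 nM, an expected step of a 3.9-fold lower number from compound 2 to compound 3 (0.59 log units; beyond the scatter).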

Compound 3, solubility: 9000 nM
Beside the measured number, compound 3's estimate shows no gap at the digits printed; the measured number falls inside the stated range.
By their numbers in this assay, from the lowest: compounds 1 and 3 (each within the scatter of the next); then compound 2.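

In this assay, the step of a 3.9-fold lower number from compound 2 to compound 3 (0.59 log units; beyond the scatter) shows that the higher number of compound 2 is not kept when pyridin-3-yl replaces 1,3,5-trimethyl-1H-pyrazol-4-yl on this aromatic carbon. The step of a 1.1-fold higher number from compound 1 to compound 3 (0.05 log units; within the scatter) leaves pyridin-3-yl and 1-methyl-1H-imidazol-4-yl indistinguishable here, so among these three groups only 1,3,5-trimethyl-1H-pyrazol-4-yl stands apart. No measurement shown gives a reason for this difference.

The compounds shown leave open whether the higher number of compound 2 goes with the pyrazole ring itself or with its methyl groups, a question that 1-methyl-1H-pyrazol-4-yl and 2,6-dimethylpyridin-3-yl would address from either side. They also leave open how this position would respond to a group carrying an amine, such as a morpholine.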